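The source may hold more compounds than are shown below. What is called first, only, known or untested is meant among the compounds shown, and "the series" means these compounds.

Notes on the series, read in a functional assay on a cell-free system (plasma, Oryctolagus cuniculus) for inhibition, with stated times of 5 min, 1 min and 6 min; a lower number here means a stronger inhibitor, a higher number a weaker inhibitor. Compound 1 (`CCOC(=O)c1c(C)nc(-c2ccc(OCC(C)C)c(C#N)c2)n1O`) gives 16800 nM and compound 2 (`CCOC(=O)c1c(C)nc(-c2ccccc2C#N)n1OC`) gives 14900 nM, two values within the scatter of each other. Compound 3 (`C=CCOn1c(-c2cccc(C#N)c2)nc(C)c1C(=O)OCC`) gives 5860 nM, the lowest of the three numbers, with both gaps beyond the scatter. Compound 4 (`CCOC(=O)c1c(C)nc(-c2cccc(C#N)c2)n1OCc1ccccc1`) differs from compound 3 by phenyl in place of vinyl on a saturated chain carbon bound to an oxygen on an aromatic ring, which reads as allyloxy to benzyloxy. Going by the values given here, no measured pair differs in one place, so no direct precedent sizes this change. The starting point is compound 3 at 5860 nM, and no step beyond the scatter is expected, with a slight lean to a lower number. The expected step is a 1.2-fold lower number from compound 3 to compound 4 (0.07 log units; within the scatter). The estimate for compound 4 is 5000 nM, within an expected range of 1800 nM to 14000 nM.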

Compound 4, half-maximal inhibitory concentration: 5930 nM
Beside the measured number, compound 4's estimate is 1.2-fold (0.07 log units) below it; the measured number falls inside the stated range.
By their numbers in this assay, from the lowest: compounds 3 and 4 (each within the scatter of the next); then compounds 2 and 1 (each within the scatter of the next).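

In this assay, going by these compounds alone, the step of a 1.0-fold higher number from compound 3 to compound 4 (0.01 log units; within the scatter) gives the first direct reading at this position: allyloxy and benzyloxy cannot be told apart. The entering phenyl brings 6 heavy atoms and an aromatic ring in place of the 2 heavy atoms and double bond of vinyl, with no shift beyond the scatter. No supporting data bear on this result.

Going by these compounds, whether a longer chain, an amine or a carboxylic acid at this place would shift the number beyond the scatter remains open.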